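The compounds below may be only part of what the source reports. "The series", "measured", "known", "first", "only" and "open" are said of these compounds alone.

Compound 1 `Cn1ncc2c1NC(=O)CN=C2c1ccccc1` in a functional assay on the whole organism (strain Holtzman) with Rattus norvegicus as the target (on this read-out lower numbers stand for an effect already at smaller amounts and higher numbers for an effect only at larger amounts of compound), gives only the limit > 80 mg/kg and no number. Compound 2 `CCc1nn(C)c2c1C(c1ccccc1)=NCC(=O)N2` gives 2.5 mg/kg. Compound 3 `CCc1nn(C)c2c1C(c1ccccc1F)=NCC(=O)N2` gives 1.25 mg/kg; 1.25 mg/kg (2 entries).

For the measured compounds named here, compound 2 thus holds the only single number among the three; compound 1 sits at a limit, compound 3 at two readings. Going by the values given here, the one measured step, an at least 32-fold lower number from compound 1 to compound 2 (1.50 log units; beyond the scatter), rests on (the limit of > 80 mg/kg in this assay, at which 1 of the 3 values shown sits), so its true size is unknown, and it concerns a different change. Compound 4 `CCc1nn(C)c2c1C(c1cccc(F)c1)=NCC(=O)N2` differs from compound 2 by fluoro in place of hydrogen on an aromatic carbon. Among the compounds with values here, no measured step matches this change; compound 3 carries a fluoro on the same phenyl at another place, and its values beside those of compound 2 stay close. Compound 4 is therefore expected to show a 1.3-fold lower number from compound 2 to compound 4 (0.10 log units; within the scatter), with an estimated value of 2 mg/kg, between 0.7 mg/kg and 6 mg/kg.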

Compound 4, minimum effective dose: 20 mg/kg
The estimate for compound 4 lay 10-fold (1.00 log units) below the measured number, outside the stated range (above it).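

In this assay, fluoro on this phenyl is no neutral change at this place: the result is an 8.0-fold higher number from compound 2 to compound 4 (0.90 log units; beyond the scatter) and lies beyond the scatter. Compound 3, with its fluoro at another place on the same phenyl, gives 1.25 mg/kg; 1.25 mg/kg (2 entries), whereas compound 4 gives 20 mg/kg, so among these compounds the place of the fluoro counts. Nothing shown here explains the change.

As far as these compounds go, whether chloro, methoxy or an amine at this same place would also raise the number stays open. So does whether a second fluoro on the phenyl would add to the change.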